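The source may hold more compounds than are shown below. What is called first, only, known or untested is meant among the compounds shown, and "the series" means these compounds.

Of the compounds shown here, three have been tested in a functional assay on HT-29 cells (Homo sapiens) for inhibition, read by sulforhodamine B assay, with a stated time of 48 h, tested at 10 uM; on this read-out lower numbers stand for less inhibition of growth and higher numbers for more inhibition of growth at the one concentration tested. Compound 1, `C/C(=N\O)c1ccc(NC(=O)Cn2nc(-c3ccc(Cl)cc3)nc2N)cc1`, gives 13.3%. Compound 2, `COc1cc(-c2nc(N)n(CC(=O)Nc3ccc(/C(C)=N\O)cc3)n2)cc(OC)c1OC`, gives 13.6% in this assay, and compound 3, `c1ccc(-c2nc3sc(-c4ccccc4)cn3n2)cc1`, gives 9%. The number of compound 1 lies within the usual scatter of both other numbers, so on these three values compound 1 cannot be set apart from compound 2 or from compound 3, and all three show only weak inhibition of growth at the single concentration tested.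

For the measured compounds named here, the next compound, compound 4, `CC(=O)c1ccc(NC(=O)Cn2nc(-c3ccc(Cl)cc3)nc2N)cc1`, keeps the core of compound 1 and changes only one group on the outer ring: a group of 3 heavy atoms (2 carbon, 1 oxygen; no ring) in place of a group of 4 heavy atoms (2 carbon, 1 nitrogen, 1 oxygen; no ring), on an aromatic carbon. Going by the values given here, no pair of measured compounds differs in a single place, so there is no measured step to lean on. Given the similar numbers seen so far, the step is expected to be small and not beyond the scatter in either direction. Compound 4 is expected to give about 12% in this assay, with a likely range from 3% to 22%. The expected step is a number 1.3 percentage points lower from compound 1 to compound 4 (within the scatter), essentially no change.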

Compound 4, percent growth inhibition at one concentration: 10.4%
Compound 4: middle estimate off by 1.6 percentage points, on the high side, within the range that was stated.
By their numbers in this assay, from the lowest: compounds 3, 4, 1 and 2 (each within the scatter of the next).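

For the compounds shown here, replacing the group on this aromatic carbon, para to a large group, with acetyl gives the first step that can be read at this position: in this assay the swap gives a number 2.9 percentage points lower from compound 1 to compound 4 (within the scatter). The group that leaves carries a hydrogen-bond donor and acetyl carries none, yet at this single concentration that difference in structure comes with no shift that can be told apart from scatter, and both compounds remain weak inhibitors of growth. Nothing measured here gives a reason for this result.

From the compounds shown here alone, whether an amine, a carboxylic acid or a longer chain on this same carbon would move the number beyond the scatter remains open. Also open, going by these compounds, is whether the two compounds would still read alike at other concentrations.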